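Exchanging a bromophenyl for methyl on a tetrabromo core

This account rests on a few compounds, and the source may have more. Where it says the series, first, only, none or still open, it means among the compounds named here.

The series rests on a shared tetrabrominated core carrying a hydroxylated chain. Compound 1 `OC(CCn1nc2c(Br)c(Br)c(Br)c(Br)c2n1)c1cccc(Br)c1` stands lowest of the three measured numbers in a functional assay on CCRF-CEM cells (Homo sapiens) for antiproliferative activity, read by MTT assay, with a stated time of 24 h, tested at 12.5 uM (on this read-out lower numbers stand for a stronger effect and higher numbers for a weaker effect at the one concentration tested), giving 102%. Compound 2 `OC(CCn1nc2c(Br)c(Br)c(Br)c(Br)c2n1)c1ccccc1` gives 122%, and compound 3 `C[C@H](O)CCn1nc2c(Br)c(Br)c(Br)c(Br)c2n1` gives 126%. Within the data shown here, the one measured step that changes a single place, a number 20 percentage points higher from compound 1 to compound 2 (beyond the scatter), weakened the effect.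

The step to be followed runs from compound 1 to compound 4 `CC(O)CCn1nc2c(Br)c(Br)c(Br)c(Br)c2n1`, where the change is methyl in place of 3-bromophenyl on a saturated chain carbon bound to an oxygen on a saturated carbon and a saturated chain carbon. Among the measured compounds shown here, no measured step removes the whole ring at that carbon, so the step from compound 1 to compound 2 bears only loosely on it, showing that taking away a bromine from that ring already pushed the number higher. Compound 3, which carries the same methyl on that carbon as compound 4, gives a number well above compound 1 and close to compound 2.

Compound 4 is therefore expected to give 124% in this assay, with a range from 108% to 140%. That estimate means a step of a number 22 percentage points higher from compound 1 to compound 4 (beyond the scatter), a weakening in line with the position of compound 3.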

Compound 4, a percentage reported as activity, at one concentration (the size of the read-out at that concentration, not a potency): 106%
Compound 4: middle estimate off by 18 percentage points, on the high side; the whole stated range lies above it.
By their numbers in this assay, from the lowest: compounds 1 and 4 (each within the scatter of the next); then compounds 2 and 3 (each within the scatter of the next).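

In this assay, methyl in place of 3-bromophenyl on this saturated chain carbon gives a number 4 percentage points higher from compound 1 to compound 4 (within the scatter) and so, unlike the loose hint from the loss of bromine alone, shows that the whole aromatic ring with its bromine can leave this position without a change beyond the scatter. Methyl in place of phenyl at the same carbon gives a number 16 percentage points lower from compound 2 to compound 4 (beyond the scatter) and so separates the two groups, which means that the ring without its bromine and the methyl do not read alike here. Among these compounds, the result also brings in a factor the earlier compounds could not show, since the same atoms and bonds give a number 20 percentage points lower from compound 3 to compound 4 (beyond the scatter) and the pair is separated by one feature alone: the fact that one of compounds 3 and 4 is drawn with a defined configuration and the other without, at the place where they differ.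

The compounds shown leave open how a form drawn with the opposite configuration at this carbon would read, and whether the gap tied to the drawn stereocentre would hold for the compounds that carry an aromatic ring there. They also leave open how a longer chain in place of the methyl, or an amine in place of the hydroxyl, would read on the shared core.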